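Working notes on the shared-core series, compound 4 pending

A few compounds are considered here, and "the series" means these few. Any claim that something is new, unique, unknown or untested is made for them only; others in the source may bear on it.

Measured so far:
compound 1 `Nc1cc(N)c2nc(-c3ccccc3)c(Oc3ccc(Cl)c(Cl)c3)nc2c1`: < 100000 nM (a limit of the assay)
compound 2 `Nc1cc(N)c2nc(-c3ccccc3)c(NCc3ccc(Cl)c(Cl)c3)nc2c1`: 3720 nM
compound 3 `Nc1cc(N)c2nc(-c3ccccc3)c(NCc3ccc(F)cc3)nc2c1`: 6310 nM

In a functional assay on RPMI8266 cells (Homo sapiens) for inhibition, read by sulforhodamine B assay, with a stated time of 48 h (on this read-out higher numbers stand for weaker inhibition of growth and lower numbers for stronger inhibition of growth), compound 3 gives 6310 nM, and compound 2 sits with it: the step of a 1.7-fold higher number from compound 2 to compound 3 (0.23 log units; within the scatter) lies within the scatter, so the two readable numbers cannot be separated. Compound 1 gives only a limit of the assay, < 100000 nM. Because of the limit of < 100000 nM in this assay, at which 1 of the 3 values shown sits, the step that the limit leaves unreadable from compound 1 to compound 3 cannot be read.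

Compound 4 `COc1ccc(Sc2nc3cc(N)cc(N)c3nc2-c2ccccc2)cc1` differs from compound 3 by (4-methoxyphenyl)sulfanyl in place of (4-fluorobenzyl)amino on an aromatic carbon. The step from compound 2 to compound 3 changes only the outer ring, not the linking group, and the step from compound 1 to compound 3 changes the linking group but is unreadable. No measured step therefore covers a sulfanyl link, and no direction can be drawn from the numbers shown. Compound 4 is expected to give an estimate of 8000 nM, within 2000 nM to 40000 nM. The estimated step of a 1.3-fold higher number from compound 3 to compound 4 (0.10 log units; within the scatter) is thus taken as none beyond the scatter, with wide uncertainty.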

Compound 4, concentration for total growth inhibition: 85100 nM
The estimate for compound 4 lay 11-fold (1.03 log units) below the measured number; measured number above the stated range.
By their numbers in this assay, from the lowest: compounds 2 and 3 (each within the scatter of the next); then compound 4.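

In this assay, within the data shown here, (4-methoxyphenyl)sulfanyl in place of (4-fluorobenzyl)amino on the aromatic carbon next to the ring nitrogen gives a 13-fold higher number from compound 3 to compound 4 (1.13 log units; beyond the scatter), the first readable step beyond the scatter at this position. Among these compounds, the only earlier readable step, a 1.7-fold higher number from compound 2 to compound 3 (0.23 log units; within the scatter), changes the outer ring alone and keeps the link, so a change of the whole group here can move the number far more than that outer-ring change did. Steps starting from compound 1 cannot be read, because compound 1 gives only a limit of the assay: the limit of < 100000 nM in this assay, at which 1 of the 4 values shown sits.

From the compounds shown here alone, the step from compound 3 to compound 4 changes the link and the ring substituent together, so the share of each stays open. A (4-methoxybenzyl)amino group or a (4-fluorophenyl)sulfanyl group at this position would separate the two.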